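The source may hold more compounds than are shown below. What is called first, only, known or untested is meant among the compounds shown, and "the series" means these compounds.

In a functional assay on aorta with Voltage-dependent L-type calcium channel subunit alpha-1C (Oryctolagus cuniculus) as the target (on this read-out higher numbers stand for weaker inhibition and lower numbers for stronger inhibition), compound 3 `CC1=NC(C)=C(C(=O)OCN2C(=O)c3ccccc3S2(=O)=O)C(c2ccccc2[N+](=O)[O-])/C1=C(\O)OC(C)C` gives 1.4 nM, the lowest of the three numbers recorded. Compound 1 `CO/C(O)=C1\C(C)=NC(C)=C(C(=O)OCN2C(=O)c3ccccc3S2(=O)=O)C1c1cccc([N+](=O)[O-])c1` gives 15.1 nM and compound 2 `CCCO/C(O)=C1\C(C)=NC(C)=C(C(=O)OCN2C(=O)c3ccccc3S2(=O)=O)C1c1cccc([N+](=O)[O-])c1` gives 64.5 nM. Compound 4 `CC1=NC(C)=C(C(=O)OCN2C(=O)c3ccccc3S2(=O)=O)C(c2ccccc2[N+](=O)[O-])/C1=C(\O)OCC1CCCCO1` carries (oxan-2-yl)methyl in place of isopropyl on an oxygen on an unsaturated carbon. Among the measured compounds shown here, the one measured step on this ester chain is a 4.3-fold higher number from compound 1 to compound 2 (0.63 log units; beyond the scatter), where a longer chain went with a higher number. Compound 3 differs from compound 1 and compound 2 in more than one place, so its gap to them says nothing on its own about the chain. A larger group entering here is therefore expected to raise the number modestly, about a 2.9-fold higher number from compound 3 to compound 4 (0.46 log units; beyond the scatter). Compound 4 is estimated at 4 nM in this assay, with a range from 1.2 nM to 14 nM.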

Compound 4, half-maximal inhibitory concentration: 25.1 nM
Compound 4: the middle estimate sits 6.3-fold (0.80 log units) below what was measured, and the stated range ends below it.
By their numbers in this assay, from the lowest: compound 3; then compounds 1 and 4 (each within the scatter of the next); then compound 2.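

On an oxygen on an unsaturated carbon, in this assay, (oxan-2-yl)methyl in place of isopropyl gives a large rise in the number (an 18-fold higher number from compound 3 to compound 4 (1.25 log units; beyond the scatter)), whereas the earlier chain step on a different core was modest (a 4.3-fold higher number from compound 1 to compound 2 (0.63 log units; beyond the scatter)). This position on the core of compound 3 is therefore sensitive to this change. Nothing available here explains the size of the rise. The compounds shown do not separate the contribution of the ring from that of its oxygen. From the compounds shown here alone, whether a cyclohexylmethyl group or a plain hexyl chain on this oxygen would behave like (oxan-2-yl)methyl remains open.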